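A few compounds are considered here, and "the series" means these few. Any claim that something is new, unique, unknown or untested is made for them only; others in the source may bear on it.

Measured so far:
Compound 1 `CCOc1ccccc1-c1ccc(-c2nc3cncc(Cl)c3c(N[C@H](CC)C(N)=O)c2C#N)cc1` gives 3.7
Compound 2 `CC[C@@H](Nc1c(C#N)c(-c2ccc(-c3cccc(C)c3)cc2)nc2cnccc12)C(N)=O` gives 3
Compound 3 `CCOc1ccccc1-c1ccc(-c2nc3cnccc3c(N[C@H](CC)C(=O)NS(=O)(=O)C3CC3)c2C#N)cc1` gives 2.3

In a physicochemical assay for lipophilicity, read by HPLC, at pH 7.5 (a lower number here means a more polar compound, a higher number a more lipophilic compound), compound 2 gives 3, the second highest of the three numbers: compound 1 stands higher, beyond the usual scatter, and compound 3 stands lower, again beyond the scatter. Compound 4 `CC[C@@H](Nc1c(C#N)c(-c2ccc(-c3ccccc3OC)cc2)nc2cnccc12)C(N)=O` has not yet been measured. It differs from compound 2 in one place: 2-methoxyphenyl in place of 3-methylphenyl on an aromatic carbon. For the measured compounds named here, no step between measured compounds matches this change, so the expectation rests on the change alone. A modest step downward in this assay is expected, probably just beyond the scatter. The step expected from this change is a number 0.50 log units lower from compound 2 to compound 4 (beyond the scatter). For compound 4 the estimate in this assay is 2.5, within a range from 2.1 to 2.9.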

Compound 4, distribution coefficient: 2.7
The estimate for compound 4 lay 0.20 log units below the measured number; measured number inside the range.
By their numbers in this assay, from the lowest: compound 3; then compounds 4 and 2 (each within the scatter of the next); then compound 1.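

In this assay there is a number 0.30 log units lower from compound 2 to compound 4 (within the scatter) when 2-methoxyphenyl replaces 3-methylphenyl on this aromatic carbon, para to a large group. For the compounds shown here, this is the first comparison here between compounds that differ in one place, and it shows that this change, which brings in an oxygen and a hydrogen-bond acceptor, leaves the reading within the usual scatter. No measurement at hand explains the result. As far as these compounds go, whether this position stays as tolerant with an amine or a carboxylic acid on that ring remains open. One pair also cannot show whether the same change behaves alike on a different core.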